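Replacing neopentyl with 1-methoxy-1-methylethyl on compound 1

The source may hold more compounds than are shown below. What is called first, only, known or untested is meant among the compounds shown, and "the series" means these compounds.

Of the compounds shown here, three have so far been measured in a functional assay on a cell-free system (plasma, Homo sapiens), with a stated time of 3 min (on this read-out lower numbers stand for stronger inhibition and higher numbers for weaker inhibition), and they span a narrow range. Compound 1 (`CC(C)(C)C[C@@H](O)C(=O)N1N=CC[C@H]1C(=O)NCc1cc(Cl)ccc1-n1cnnn1`) gives 590 nM and is the strongest inhibitor of the three. Compound 2 (`CC(C)(C)[C@@H](O)C(=O)N1C[C@H]2C[C@H]2[C@H]1C(=O)NCc1cc(Cl)ccc1-n1cnnn1`) gives 1200 nM and compound 3 (`CC(C)(C)[C@@H](O)C(=O)N1[C@H](C(=O)NCc2cc(Cl)ccc2-n2cnnn2)C[C@@H]2C[C@@H]21`) gives 1500 nM in the same read-out, and each of them lies beyond the usual scatter from compound 1.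

The next compound, compound 4 (`COC(C)(C)[C@@H](O)C(=O)N1N=CC[C@H]1C(=O)NCc1cc(Cl)ccc1-n1cnnn1`), keeps the core of compound 1 and carries 1-methoxy-1-methylethyl in place of neopentyl on a saturated chain carbon bound to a carbonyl carbon and an oxygen on a saturated carbon. For the measured compounds named here, no two measured compounds differ in one place only, so the data hold no direct precedent for this exchange and the expectation is a loose one. It starts from compound 1 at 590 nM and anticipates a small rise in the number in this assay rather than a fall. The expected change is a 1.4-fold higher number from compound 1 to compound 4 (0.13 log units; within the scatter) and it would remain within the scatter. For compound 4 the estimated value is 800 nM with an expected range from 250 nM to 2500 nM in this measurement.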

Compound 4, half-maximal inhibitory concentration: 3700 nM
For compound 4 the middle estimate is 4.6-fold (0.67 log units) below the measured one; measured number outside the range, above it.
By their numbers in this assay, from the lowest: compound 1; then compounds 2 and 3 (each within the scatter of the next); then compound 4.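

In this assay, for the compounds shown here, the exchange of neopentyl for 1-methoxy-1-methylethyl on a saturated chain carbon bound to a carbonyl carbon and an oxygen on a saturated carbon gives a 6.3-fold higher number from compound 1 to compound 4 (0.80 log units; beyond the scatter) and is the first change in the set confined to one place. With the core of compound 1 held, the position does not treat the two groups alike, although both hold 5 heavy atoms and neither has a ring or a net charge; by the counts, 1-methoxy-1-methylethyl differs from neopentyl in holding 1 oxygen and 1 hydrogen-bond acceptor. Nothing available bears on the origin of this rise, so the step gives its size and no explanation.

The compounds shown leave open whether the oxygen itself or the altered branching of the group goes with the weaker inhibition, a question that 1-hydroxy-1-methylethyl or 1-ethoxy-1-methylethyl at this place could help to separate. They also leave open whether the same exchange would have a similar effect on the cores of compound 2 and compound 3.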